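Chlorine removal on the aryl ring of compound 1

The source may report more compounds than this note shows. Statements on the series, on what has been measured and on what is new or still open speak of the compounds shown alone.

Compound 1 `COc1cc(/C=C/C(=O)c2cccc(-n3cc(-c4ccc(Cl)cc4)[nH]c3=O)c2)cc(OC)c1OC` and compound 2 `O=C(/C=C/c1cccc(O)c1)c1cccc(-n2cc(-c3ccc(Cl)cc3)[nH]c2=O)c1` have been measured in a functional assay on OVCAR-5 cells (Homo sapiens) for inhibition; on this read-out lower numbers stand for stronger inhibition of growth and higher numbers for weaker inhibition of growth. In this assay compound 1 gives 3110 nM, and compound 2 gives 2190 nM; these two numbers lie within the scatter of each other, so neither stands apart. Compound 3 `COc1cc(/C=C/C(=O)c2cccc(-n3cc(-c4ccccc4)[nH]c3=O)c2)cc(OC)c1OC` has not been measured. It differs from compound 1 by hydrogen in place of chloro on an aromatic carbon. For the measured compounds named here, no pair of measured compounds differs in a single place, so there is no measured step to draw on; a step of about the size of the scatter, toward weaker inhibition, is expected as a 1.3-fold higher number from compound 1 to compound 3 (0.11 log units; within the scatter). Compound 3 is therefore estimated at 4000 nM, within a range of 1500 nM to 10000 nM.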

Compound 3, concentration for 50% growth inhibition: 1880 nM
Beside the measured number, compound 3's estimate is 2.1-fold (0.33 log units) above it, and the stated range covers the measured number.
By their numbers in this assay, from the lowest: compounds 3, 2 and 1 (each within the scatter of the next).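

Hydrogen in place of chloro on the aromatic carbon para to a large group gives the first single-place step in the series: in this assay it reads a 1.7-fold lower number from compound 1 to compound 3 (0.22 log units; within the scatter). For this pair, growth inhibition in this assay therefore does not depend on the chloro group, as 4-chlorophenyl and phenyl cannot be told apart. Nothing available bears on the size of this step.

As far as these compounds go, whether an amine or a carboxylic acid at this place would give a step beyond the scatter remains open. So does whether the same change on compound 2 would give a similar step.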